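From hydroxybenzyl back to hydroxycyclohexyl

A few compounds are considered here, and "the series" means these few. Any claim that something is new, unique, unknown or untested is made for them only; others in the source may bear on it.

- compound 1 `O=C(NCCNS(=O)(=O)c1ccc(-c2ccccc2O[C@H]2CC[C@H](O)CC2)s1)Nc1cc(C(F)(F)F)cc(C(F)(F)F)c1`: 10100 nM
- compound 2 `O=C(NCCNS(=O)(=O)c1ccc(-c2ccccc2OCc2cccc(O)c2)s1)Nc1cc(C(F)(F)F)cc(C(F)(F)F)c1`: 3000 nM

Both values come from a functional assay on RS4-11 cells (Homo sapiens) for inhibition, read by CCK-8 assay, with a stated time of 48 h; on this read-out lower numbers stand for stronger inhibition and higher numbers for weaker inhibition. Within the data shown here, of these two numbers, compound 2 holds the lower, at 3000 nM, and the gap to its only neighbour is a 3.4-fold lower number from compound 1 to compound 2 (0.53 log units; beyond the scatter).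

The next compound to be tested is compound 3 `O=C(NCCNS(=O)(=O)c1ccc(-c2ccccc2O[C@H]2CC[C@@H](O)CC2)s1)Nc1cc(C(F)(F)F)cc(C(F)(F)F)c1`. Relative to compound 2, it carries 4-hydroxycyclohexyl in place of 3-hydroxybenzyl on an oxygen on an aromatic ring.

Among the measured compounds shown here, only one measured step bears on this change, and it is the exchange of the same two named groups in the opposite direction: a 3.4-fold lower number from compound 1 to compound 2 (0.53 log units; beyond the scatter). That step is modest in size. Reversing it leads to the expectation of a higher number in this assay, by a similar amount. For the measured compounds named here, no measured step shows what the arrangement of the defined stereocentres in compound 3 contributes, so the expectation remains loose.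

The expected change is a 2.5-fold higher number from compound 2 to compound 3 (0.40 log units; beyond the scatter). For compound 3 the estimated value is 7500 nM, with an expected range from 2500 nM to 20000 nM.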

Compound 3, half-maximal inhibitory concentration: 9300 nM
Compound 3: the middle estimate sits 1.2-fold (0.09 log units) below what was measured, within the range that was stated.
By their numbers in this assay, from the lowest: compound 2; then compounds 3 and 1 (each within the scatter of the next).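

In this assay there is a 3.1-fold higher number from compound 2 to compound 3 (0.49 log units; beyond the scatter), so the exchange of 3-hydroxybenzyl for 4-hydroxycyclohexyl on an oxygen on an aromatic ring now goes with a higher number for both drawn configurations of the saturated ring. The two 4-hydroxycyclohexyl compounds themselves cannot be told apart, with a 1.1-fold lower number from compound 1 to compound 3 (0.04 log units; within the scatter). This pair isolates the configuration at the saturated ring carbons and shows that, in this assay, inverting both stereocentres leaves the number within the scatter, so the gap to compound 2 follows the change of group and not the drawn arrangement, a reading that rests on this: the fact that compounds 1 and 3 differ only in the configuration as drawn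

The compounds shown leave open which feature of 3-hydroxybenzyl goes with the lower number of compound 2, at 3000 nM, whether the aromatic ring, the one-carbon link to the oxygen or the place of the hydroxyl. As far as these compounds go, an unsubstituted benzyl, a 4-hydroxybenzyl, a plain cyclohexyl or a cyclohexylmethyl on the same oxygen would separate these, and whether an amine or a carboxylic acid in place of the hydroxyl would move the number also remains unknown.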